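A few compounds are considered here, and "the series" means these few. Any claim that something is new, unique, unknown or untested is made for them only; others in the source may bear on it.

Measured so far: compound 1 `CCCCCCOc1ccc(-n2cnnc2CCCCCC)cc1`, compound 2 `CCCCCCCCCc1nncn1-c1ccc(OCCCCCC)cc1`.

In a functional assay on the whole organism (strain C57B/6) with Mus musculus as the target, in the maximal electroshock model (a lower number here means that less compound is needed, a higher number that more compound is needed for the effect), compound 1 gives > 40 mg/kg, which is a limit of the assay and not a number. In this assay compound 2 gives > 40 mg/kg, again only a limit. The step that the two limits leave unreadable from compound 1 to compound 2 is thus unreadable; both values sit at the limit of > 40 mg/kg in this assay, at which 2 of the 2 values shown sit. Compound 3 `CCCCCCOc1ccc(-n2cnnc2-c2cccc(F)c2)cc1` differs from compound 1 by 3-fluorophenyl in place of hexyl on an aromatic carbon. Within the data shown here, no measured step bears readably on this change, so no direction can be drawn from the series. Compound 3 is therefore expected to sit near the same limit, with a number no higher from compound 1 to compound 3 (the limit leaves the size open), an estimate of 40 mg/kg and a range from 12 mg/kg to 130 mg/kg.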

Compound 3, dose for half-maximal effect: 27.4 mg/kg
Beside the measured number, compound 3's estimate is 1.5-fold (0.16 log units) above it; measured number inside the range.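

In this assay compound 3 is the only compound shown that gives a number and not a limit, so an aromatic group at this aromatic carbon of the five-membered ring still leaves a readable value. The step with hexyl leaving is an at least 1.4-fold lower number from compound 1 to compound 3 (0.16 log units; that floor lies within the scatter), and with nonyl leaving it is an at least 1.4-fold lower number from compound 2 to compound 3 (0.16 log units; that floor lies within the scatter). Both steps are floors only, because the values they start from are limits: the limit of > 40 mg/kg in this assay, at which 2 of the 3 values shown sit.

As far as these compounds go, what plain phenyl or a phenyl bearing an amine would give at this position stays open. So does the outcome for a chain shorter than hexyl here.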